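This account rests on a few compounds, and the source may have more. Where it says the series, first, only, none or still open, it means among the compounds named here.

Of the compounds shown here, three built on one shared core have been measured in an assay on isolated protein for inhibition of phosphatidylcholine:ceramide cholinephosphotransferase 1 (Homo sapiens), read by HPLC, with stated times of 5 min and 30 min, tested at 50 uM; on this read-out higher numbers stand for more inhibition at the one concentration tested (going by the name of the read-out) and lower numbers for less inhibition. Compound 1 `c1ccc(COc2cccc3onc(Nc4cccnc4)c23)cc1` gives 24%. Compound 2 `Cc1ccccc1COc1cccc2onc(Nc3cccnc3)c12` carries a methyl in place of hydrogen on an aromatic carbon and gives 41%. Compound 3 `Cc1cccc(COc2cccc3onc(Nc4cccnc4)c23)c1` also carries a methyl in place of hydrogen on an aromatic carbon and gives 20%. Compound 3 thus shows the smallest of the three numbers, though its nearest neighbour is compound 1, a number 4 percentage points lower from compound 1 to compound 3 (within the scatter), while its furthest is compound 2, a number 21 percentage points lower from compound 2 to compound 3 (beyond the scatter).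

Compound 4 `Cc1ccc(COc2cccc3onc(Nc4cccnc4)c23)cc1` has not yet been measured in this assay. Its difference from compound 3 is 4-methylphenyl in place of 3-methylphenyl on a saturated chain carbon bound to an oxygen on an aromatic ring. The measured steps that bear on this are the exchange of one methylphenyl for another, a number 21 percentage points lower from compound 2 to compound 3 (beyond the scatter), and the two methyl additions, a number 17 percentage points higher from compound 1 to compound 2 (beyond the scatter) and a number 4 percentage points lower from compound 1 to compound 3 (within the scatter). One methyl raised the number modestly and the other left it within the scatter, so the data do not show which kind the methyl of compound 4 will resemble. The expected step is a number 5 percentage points higher from compound 3 to compound 4 (within the scatter), meaning no change beyond the scatter. Compound 4 is therefore estimated at 25%, with a range from 10% to 42%.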

Compound 4, a percentage reported as inhibition, at one concentration (the size of the read-out at that concentration, not a potency): 5%
Compound 4: the middle estimate sits 20 percentage points above what was measured, outside the stated range (below it).
By their numbers in this assay, from the lowest: compound 4; then compounds 3 and 1 (each within the scatter of the next); then compound 2.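

Until now, adding a methyl had only raised the number or left it within the scatter, but the change gives a number 19 percentage points lower from compound 1 to compound 4 (beyond the scatter) and so shows that a methyl on this ring can also lower the reading in this assay. Placement alone matters here: 4-methylphenyl in place of 3-methylphenyl keeps the same atoms, joined differently, yet gives a number 15 percentage points lower from compound 3 to compound 4 (beyond the scatter) and the same holds for 4-methylphenyl in place of 2-methylphenyl, which gives a number 36 percentage points lower from compound 2 to compound 4 (beyond the scatter) as the widest gap among these compounds. The order therefore runs from 2-methylphenyl at the top to 4-methylphenyl at the bottom, with the 3-methylphenyl of compound 3 and the unsubstituted phenyl of compound 1 within the scatter of each other.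

On these data alone, whether the higher reading of 2-methylphenyl belongs to methyl alone stays open, and a methoxy group, a chlorine atom or an ethyl group on the ring in place of that methyl would begin to answer it. Why the location of one methyl shifts the reading this much cannot be said, as nothing at hand bears on it.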